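This account rests on a few compounds, and the source may have more. Where it says the series, first, only, none or still open, it means among the compounds named here.

In an ADME assay on LLC-PK11 cells (Sus scrofa) for cytotoxicity, read by neutral red uptake, with a stated time of 48 h (on this read-out lower numbers stand for stronger inhibition and higher numbers for weaker inhibition), compound 2 (`Cc1cc(NCCCCCCNc2ccnc3cc(Cl)ccc23)nc(N2CCN(C)CC2)n1`) gives 7200 nM and stands within the scatter of compound 1 (`CCN1CCN(c2nc(C)cc(NCCCCNc3ccnc4cc(Cl)ccc34)n2)CC1`), which gives 10700 nM in the same read-out. Compound 3 (`Cc1cc(NCCCNc2ccnc3cc(Cl)ccc23)nc(N2CCN(C)CC2)n1`) gives 34600 nM as a higher number than compound 2, beyond the scatter. Compound 4 (`Cc1cc(NCCCCCCNc2ccnc3cc(Cl)ccc23)nc(Cl)n1`) carries chloro in place of 4-methylpiperazin-1-yl on an aromatic carbon and otherwise matches compound 2. Going by the values given here, no measured pair differs in one place, and no measured compound carries chloro there, so the data give no direct guide to this change. The estimated step (a 1.7-fold higher number from compound 2 to compound 4 (0.22 log units; within the scatter)) in this assay is small, toward a higher number and within the scatter. Compound 4 is expected at 12000 nM (estimated range 4000 nM to 35000 nM).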

Compound 4, half-maximal inhibitory concentration: 15800 nM
Beside the measured number, compound 4's estimate is 1.3-fold (0.12 log units) below it; low and high end bracket the measured number.
By their numbers in this assay, from the lowest: compounds 2, 1 and 4 (each within the scatter of the next, the first and the last beyond it); then compound 3.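

In this assay, this position between two ring nitrogen atoms responds only modestly to a large change: chloro in place of 4-methylpiperazin-1-yl gives a 2.2-fold higher number from compound 2 to compound 4 (0.34 log units; beyond the scatter). The whole non-aromatic ring and its hydrogen-bond acceptors leave, yet the step remains modest. Nothing measured on these compounds accounts for the step.

Open, on these data alone, is where a morpholine ring or a dimethylamino group at this position would fall relative to compound 2 and compound 4. Also open, as far as these compounds go, is whether the same change gives a similar step on a shorter chain.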